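Swapping the heteroaryl cap on a sulfonamide nitrogen

This account rests on a few compounds, and the source may have more. Where it says the series, first, only, none or still open, it means among the compounds named here.

Three measured compounds share one core and were tested in a functional assay on MDA-MB-231 cells (Homo sapiens) for antiproliferative activity, read by sulforhodamine B assay, with a stated time of 48 h; on this read-out lower numbers stand for stronger inhibition and higher numbers for weaker inhibition. Compound 2 `Cc1noc(NS(=O)(=O)c2ccc(N/C(S)=N\c3ccnc4cc(C(F)(F)F)ccc34)cc2)c1C` gives 27900 nM. Compound 1 `Nc1ccc(S(=O)(=O)Nc2ccnc3cc(C(F)(F)F)ccc23)cc1` gives 31000 nM, and compound 3 `Cc1cc(C)nc(NS(=O)(=O)c2ccc(N/C(S)=N\c3ccnc4cc(C(F)(F)F)ccc34)cc2)n1` gives 52900 nM. Compound 2 thus stands at the lowest number of the three, but its gap to compound 1 and its gap to compound 3 both lie within the usual scatter of repeated measurements, so the three cannot really be told apart on these numbers. Going by the values given here, the only step between two compounds that differ in a single place is the exchange of the cap on the sulfonamide nitrogen, which gave a 1.9-fold higher number from compound 2 to compound 3 (0.28 log units; within the scatter), a change within the scatter.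

Compound 4 `COc1ncnc(NS(=O)(=O)c2ccc(N/C(S)=N\c3ccnc4cc(C(F)(F)F)ccc34)cc2)c1OC` has not yet been measured. It differs from compound 2 by 5,6-dimethoxypyrimidin-4-yl in place of 3,4-dimethyl-1,2-oxazol-5-yl on a sulfonamide nitrogen. Among the compounds with values here, this is again a swap of one heteroaryl cap for another at the same place, and the one measured step of that kind stayed within the scatter. A step beyond the scatter is therefore not expected here, in either direction; the expected step from compound 2 to compound 4 is a 1.1-fold higher number from compound 2 to compound 4 (0.03 log units; within the scatter). For compound 4 in this assay the estimate is 30000 nM, with a range from 10000 nM to 90000 nM.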

Compound 4, half-maximal inhibitory concentration: 83000 nM
Beside the measured number, compound 4's estimate is 2.8-fold (0.44 log units) below it; the range from low to high includes it.
By their numbers in this assay, from the lowest: compounds 2, 1, 3 and 4 (each within the scatter of the next, the first and the last beyond it).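

Going by these compounds alone, the cap on the sulfonamide nitrogen can move the number beyond the scatter in this assay: placing 5,6-dimethoxypyrimidin-4-yl where 3,4-dimethyl-1,2-oxazol-5-yl stood gives a 3.0-fold higher number from compound 2 to compound 4 (0.47 log units; beyond the scatter), a modest step, whereas the only earlier swap at this place stayed within the scatter. The two six-membered caps, by contrast, cannot be told apart, as exchanging 4,6-dimethylpyrimidin-2-yl for 5,6-dimethoxypyrimidin-4-yl gives a 1.6-fold higher number from compound 3 to compound 4 (0.20 log units; within the scatter), which is within the scatter. This is no general rule that six-membered caps differ from the five-membered one, since compound 3 also carries a six-membered cap and its step from compound 2 lies within the scatter, so only compound 4 stands apart from compound 2.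

The compounds shown leave open whether a cap bearing an amine or a carboxylic acid in place of the two methoxy groups would stay close to compound 4 or shift the number further. Nothing measured here accounts for the step from compound 2 to compound 4.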